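The compounds below may be only part of what the source reports. "The series", "measured", "known", "first", "only" and "open" are said of these compounds alone.

Values in a functional assay on DU-145 cells (Homo sapiens) for inhibition, read by trypan blue exclusion, with a stated time of 96 h; on this read-out higher numbers stand for weaker inhibition of growth and lower numbers for stronger inhibition of growth:
- compound 1 `CSc1ccc(/C=C(/SCc2ccc(Br)cc2)C(=O)c2ccc(C(=O)O)cc2)cc1`: 10000 nM
- compound 2 `O=C(O)c1ccc(C(=O)/C(=C\c2ccc(O)c(Br)c2)SCc2ccc(Br)cc2)cc1`: 25000 nM

Of the two measured compounds, compound 2 at 25000 nM carries the higher number and so shows the weaker inhibition of growth. Its nearest neighbour is compound 1, and the gap lies beyond the scatter.

Next is compound 3 `O=C(O)c1ccc(C(=O)/C(=C\c2ccccc2F)SCc2ccc(Br)cc2)cc1`, not yet measured. The change is 2-fluorophenyl in place of 3-bromo-4-hydroxyphenyl on a double-bonded chain carbon bound to a double-bonded chain carbon. Among the measured compounds shown here, only one measured step bears on it: a 2.5-fold higher number from compound 1 to compound 2 (0.40 log units; beyond the scatter). That step is modest and falls at the same place, on a double-bonded chain carbon bound to a double-bonded chain carbon. It shows that the 3-bromo-4-hydroxyphenyl compound gives the higher number of this pair, so losing that group is expected to move the number down, towards the value of compound 1 at 10000 nM. For the measured compounds named here, no compound with 2-fluorophenyl has been measured, so the direction remains tentative and the range stays wide.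

The expected move in this assay is modest: a 2.1-fold lower number from compound 2 to compound 3 (0.32 log units; beyond the scatter). For compound 3 the estimate is 12000 nM, with an expected range of 4000 nM to 30000 nM.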

Compound 3, concentration for 50% growth inhibition: 10000 nM
Estimate against measurement, compound 3: 1.2-fold (0.08 log units) above; the range from low to high includes it.
By their numbers in this assay, from the lowest: compounds 1 and 3 (each within the scatter of the next); then compound 2.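

In this assay, at the place on a double-bonded chain carbon bound to a double-bonded chain carbon, 2-fluorophenyl in place of 3-bromo-4-hydroxyphenyl gives a 2.5-fold lower number from compound 2 to compound 3 (0.40 log units; beyond the scatter) and so shows that the higher number of compound 2 is not shared by the other two groups tried here. Among the compounds shown here, the comparison with the other low compound gives no change at the digits printed from compound 1 to compound 3 (within the scatter) and so shows that 2-fluorophenyl and 4-(methylsulfanyl)phenyl cannot be told apart at this place, leaving 3-bromo-4-hydroxyphenyl as the one group of the three that stands apart. The step from compound 2 to compound 3 removes the hydroxyl and the bromine together, so the two cannot be separated, and nothing available explains the difference between these groups.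

Open, going by these compounds, is whether either the hydroxyl or the bromine alone accounts for the higher number of compound 2, which a plain 4-hydroxyphenyl or 3-bromophenyl group would address. Also open, on these data alone, is whether any group at this place, such as a 4-aminophenyl or a 4-methoxyphenyl group, can bring the number below that shared by compound 1 and compound 3.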